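This account rests on a few compounds, and the source may have more. Where it says the series, first, only, none or still open, it means among the compounds named here.

In a functional assay on CEM-DNR-bulk cells (Homo sapiens), read by MTT assay, with a stated time of 72 h (on this read-out lower numbers stand for stronger inhibition and higher numbers for weaker inhibition), compound 1 (`Cc1nc(N)c2c(-c3ccco3)cn([C@@H]3O[C@H](CO)[C@@H](O)[C@H]3O)c2n1`) gives > 20000 nM, which is a limit of the assay and not a number. Compound 2 (`Cc1nc(N)c2c(-c3ccsc3)cn([C@@H]3O[C@H](CO)[C@@H](O)[C@H]3O)c2n1`) gives > 20000 nM, again a limit. Among the compounds with values here, compound 3 (`Cc1nc(N)c2c(-c3cc4ccccc4o3)cn([C@@H]3O[C@H](CO)[C@@H](O)[C@H]3O)c2n1`) gives 6310 nM, the only true number in the set so far.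

Next in line is compound 4 (`C#Cc1cn([C@@H]2O[C@H](CO)[C@@H](O)[C@H]2O)c2nc(C)nc(N)c12`). The change is ethynyl in place of 1-benzofuran-2-yl on an aromatic carbon, two ring bonds from the ring nitrogen.

Within the data shown here, two measured steps bear on this, and both concern the group that leaves: an at least 3.1-fold lower number from compound 1 to compound 3 (0.50 log units; beyond the scatter) and an at least 3.1-fold lower number from compound 2 to compound 3 (0.50 log units; beyond the scatter). Both lie beyond the scatter, and both are bounded on one side only. Among these three compounds, 1-benzofuran-2-yl is the one group that comes off the limit, while furan-2-yl and thiophen-3-yl do not. Ethynyl has no ring and is a new kind of group for this series, so the read-across is loose. On the gain seen in an at least 3.1-fold lower number from compound 2 to compound 3 (0.50 log units; beyond the scatter), a modest move to a higher number in this assay is expected, with a real chance of a reading at the limit. The expected step is a 2.5-fold higher number from compound 3 to compound 4 (0.40 log units; beyond the scatter). For compound 4 the estimated value is 16000 nM, with an expected range of 3000 nM to 20000 nM.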

Compound 4, half-maximal inhibitory concentration: 12600 nM
Compound 4: middle estimate off by 1.3-fold (0.10 log units), on the high side; the measured number falls inside the stated range.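

In this assay, ethynyl at this position, two ring bonds from the ring nitrogen, gives a second reading off the limit, and a 2.0-fold higher number from compound 3 to compound 4 (0.30 log units; within the scatter) leaves compound 3 and compound 4 without an order. Among the four compounds shown, a readable number therefore does not depend on the fused aromatic system of 1-benzofuran-2-yl, since a group with no ring also gives one, while the single rings thiophen-3-yl and furan-2-yl do not. Against those two rings the steps are an at least 1.5-fold lower number from compound 2 to compound 4 (0.20 log units; that floor lies within the scatter) and an at least 1.5-fold lower number from compound 1 to compound 4 (0.20 log units; that floor lies within the scatter), and they remain floors because the two compounds bearing these rings sit at a limit and not at a number: the limit of > 20000 nM in this assay, at which 2 of the 4 values shown sit.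

Whether ethynyl truly improves on thiophen-3-yl and furan-2-yl therefore stays unsettled, as the true size of both steps cannot be read. Also open, as far as these compounds go, is what a phenyl ring, an aminomethyl group or a longer alkynyl chain would give at this position, and whether any of them would move the number well beyond the scatter from compound 3 and compound 4.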